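Hydroxypiperidine in place of cyclopentylpiperazine on the shared core

A few compounds are considered here, and "the series" means these few. Any claim that something is new, unique, unknown or untested is made for them only; others in the source may bear on it.

Compound 1 `Cc1nc(N2CCN(C3CCCC3)CC2)nc2ccc(NC(=O)COc3ccc(Cl)cc3)cc12` gives the highest of the measured numbers in a functional assay on CHO-K1 cells for antagonist activity at melanin-concentrating hormone receptor 1 (Homo sapiens), read by inositol phosphate accumulation (a lower number here means a stronger inhibitor, a higher number a weaker inhibitor), at 150 nM. Compound 2 `CCC1(O)CCN(c2nc(C)c3cc(NC(=O)COc4ccc(OC(F)(F)F)cc4)ccc3n2)CC1` gives 59 nM in this assay, and compound 3 `Cc1nc(N2CCC(O)(C3CC3)CC2)nc2ccc(NC(=O)COc3ccc(OC(F)(F)F)cc3)cc12` gives 33 nM, both beyond the scatter from compound 1. Within the data shown here, the one measured step, a 1.8-fold lower number from compound 2 to compound 3 (0.25 log units; within the scatter), concerns a different position and a different aryl ether, so it does not bear directly on compound 4 `Cc1nc(N2CCC(O)CC2)nc2ccc(NC(=O)COc3ccc(Cl)cc3)cc12`. The change here is 4-hydroxypiperidin-1-yl in place of 4-cyclopentylpiperazin-1-yl on an aromatic carbon. Among the measured compounds shown here, compounds 2 and 3 show that a hydroxypiperidine on this carbon is compatible with numbers below that of compound 1, but no step isolates this exchange. The step of a 1.4-fold lower number from compound 1 to compound 4 (0.13 log units; within the scatter) is therefore expected to be small, with a wide range. Compound 4 is estimated at 110 nM, between 30 nM and 400 nM.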

Compound 4, half-maximal inhibitory concentration: 163 nM
Compound 4: middle estimate off by 1.5-fold (0.17 log units), on the low side; the measured number falls inside the stated range.
By their numbers in this assay, from the lowest: compounds 3 and 2 (each within the scatter of the next); then compounds 1 and 4 (each within the scatter of the next).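

With the rest of compound 1 held fixed, the step in this assay is a 1.1-fold higher number from compound 1 to compound 4 (0.04 log units; within the scatter), so 4-hydroxypiperidin-1-yl and 4-cyclopentylpiperazin-1-yl cannot be told apart on this aromatic carbon. The cyclopentyl ring and the second piperazine nitrogen can therefore both go from this position without a readable change in the number. Nothing shown gives a reason for this result. Still open, from the compounds shown here alone, is whether a plain piperidine without the hydroxyl would match these two, and whether an amine or a methoxy group could take the place of that hydroxyl.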